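The source may report more compounds than this note shows. Statements on the series, on what has been measured and on what is new or still open speak of the compounds shown alone.

In an assay on cells for displacement of a labelled ligand from transmembrane domain-containing protein TMIGD3 (Homo sapiens), read by scintillation counting, with a stated time of 120 min, tested at 1 uM (a lower number here means less inhibition, a higher number more inhibition at the concentration tested (going by the name of the read-out)), compound 1 `Nc1nccn2cc(-c3ccco3)nc12` gives 5%. Compound 2 `Nc1nc(Br)cn2cc(-c3ccco3)nc12` gives 28% and compound 3 `Nc1nc(-c2ccccc2)cn2cc(-c3ccco3)nc12` gives 21%; compound 3 thus stands second highest of the three numbers, within the scatter of compound 2 and beyond the scatter from compound 1. The change to compound 4 `Nc1nc(-c2ccco2)cn2cc(-c3ccco3)nc12` is furan-2-yl in place of phenyl on an aromatic carbon. Among the measured compounds shown here, two measured steps bear on it: a number 16 percentage points higher from compound 1 to compound 3 (beyond the scatter) and a number 23 percentage points higher from compound 1 to compound 2 (beyond the scatter), each a modest rise when a group replaces hydrogen on that aromatic carbon, while a number 7 percentage points lower from compound 2 to compound 3 (within the scatter) shows that swapping one such group for another changes little. A furan-2-yl ring is expected to act much like phenyl here, so the expected step is a number 1 percentage points higher from compound 3 to compound 4 (within the scatter), none beyond the scatter. Compound 4 is therefore estimated at 22%, with a range from 8% to 38%.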

Compound 4, a percentage reported as inhibition, at one concentration (the size of the read-out at that concentration, not a potency): 38%
Beside the measured number, compound 4's estimate is 16 percentage points below it, within the range that was stated.
By their numbers in this assay, from the lowest: compound 1; then compounds 3, 2 and 4 (each within the scatter of the next, the first and the last beyond it).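

In this assay, among the compounds shown here, the two aromatic rings at this position are not interchangeable: replacing phenyl with furan-2-yl gives a number 17 percentage points higher from compound 3 to compound 4 (beyond the scatter), the first swap of one group for another here to exceed the scatter. For the compounds shown here, replacing bromo with furan-2-yl gives a number 10 percentage points higher from compound 2 to compound 4 (within the scatter), while replacing hydrogen gives a number 33 percentage points higher from compound 1 to compound 4 (beyond the scatter), the only large step so far. Nothing available explains the difference between the two rings. As far as these compounds go, whether the oxygen of the furan-2-yl ring matters remains open. So does how an amine, a carboxylic acid or a longer chain would read at this position.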